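Adding a Hydroxy Group to the Outer Amide Ring

This account rests on a few compounds, and the source may have more. Where it says the series, first, only, none or still open, it means among the compounds named here.

Among the measured compounds shown here, compound 1 `CN(C)C(=O)c1cc2cnc(Nc3ccc(NC(=O)C4(C(=O)Nc5ccccc5)CC4)cc3)nc2n1C1CCCC1` is one of three compounds measured so far. In a functional assay on OVCAR-5 cells (Homo sapiens) for inhibition, read by CCK-8 assay, with a stated time of 72 h, tested at 10 uM (a higher number here means more inhibition of growth at the concentration tested, a lower number less inhibition of growth), compound 1 gives 77.1% and stands second highest of the three numbers. Compound 3 `CN(C)C(=O)c1cc2cnc(Nc3ccc(NC(=O)C4(C(=O)Nc5cccc(Br)c5)CC4)cc3)nc2n1C1CCCC1` gives 89.6% in this assay while compound 2 `CN(C)C(=O)c1cc2cnc(Nc3ccc(NC(=O)C4(C(=O)Nc5ccc(Cl)c(C(F)(F)F)c5)CC4)cc3)nc2n1C1CCCC1` gives 48% in the same test. The two measured steps that start from compound 1 point in opposite directions: a number 12.5 percentage points higher from compound 1 to compound 3 (beyond the scatter) whereas a number 29.1 percentage points lower from compound 1 to compound 2 (beyond the scatter) and the remaining step of a number 41.6 percentage points higher from compound 2 to compound 3 (beyond the scatter) ties the two ends together.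

Compound 4 `CN(C)C(=O)c1cc2cnc(Nc3ccc(NC(=O)C4(C(=O)Nc5ccc(O)cc5)CC4)cc3)nc2n1C1CCCC1` has not yet been measured. It differs from compound 1 by hydroxy in place of hydrogen on an aromatic carbon so it alters the same ring that both measured steps alter. Those steps bear on the question but neither brings in a hydroxy group: the bromo substitution lifted the number modestly while the change to 4-chloro-3-(trifluoromethyl)phenyl lowered it more strongly. Because a number 12.5 percentage points higher from compound 1 to compound 3 (beyond the scatter) and a number 29.1 percentage points lower from compound 1 to compound 2 (beyond the scatter) disagree in sign and neither brings in the new group, the expected step is one that stays within or only just beyond the scatter: a number 3.1 percentage points lower from compound 1 to compound 4 (within the scatter) is the estimate. Compound 4 is therefore expected to give about 74% in this assay with a likely range from 55% to 90%.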

Compound 4, percent growth inhibition at one concentration: 90.9%
Estimate against measurement, compound 4: 16.9 percentage points below; measured number outside the range, above it.
By their numbers in this assay, from the lowest: compound 2; then compound 1; then compounds 3 and 4 (each within the scatter of the next).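

In this assay, among the compounds shown here, changing phenyl to 4-hydroxyphenyl gives a number 13.8 percentage points higher from compound 1 to compound 4 (beyond the scatter), so a group on this ring that brings a hydrogen-bond donor and acceptor can raise the number, and no earlier compound carried such a group. A hydroxy group and a bromo group on this ring give numbers that cannot be told apart, with a number 1.3 percentage points higher from compound 3 to compound 4 (within the scatter), even though the two groups differ in kind and in where they sit. Filling the place para to the large group does not raise the number in every case: compound 2, with its 4-chloro-3-(trifluoromethyl)phenyl, goes against that idea, as a number 42.9 percentage points higher from compound 2 to compound 4 (beyond the scatter) shows, and no measurement available here explains the difference.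

Still open, from the compounds shown here alone, is whether the rise belongs to the hydroxy group itself, which a methoxy group or an amine in the same place would help to settle. Also open, going by these compounds, is whether the hydroxy group needs this exact place, which 3-hydroxyphenyl would test, and whether a carboxylic acid on the ring would be accepted as well.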